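Replacing the pyridinyl arm with a chlorohydroxyphenyl group

The source may report more compounds than this note shows. Statements on the series, on what has been measured and on what is new or still open speak of the compounds shown alone.

Measured compounds in a functional assay on SW-620 cells (Homo sapiens) for antiproliferative activity, read by MTT assay, with a stated time of 24 h; a higher number here means a weaker inhibitor, a lower number a stronger inhibitor:
compound 1, `COc1ccc(C(=O)/C=C/c2ccc([N+](=O)[O-])cc2)c2c1C=CC(C)(C)O2`: 3520 nM
compound 2, `COc1ccc(/C=C/C(=O)c2ccc(OC)c3c2OC(C)(C)C=C3)cn1`: > 10000 nM
compound 3, `COc1ccc(C(=O)/C=C/c2ccccn2)c2c1C=CC(C)(C)O2`: 5000 nM

The three compounds share one core and differ only in the aryl group on a double-bonded chain carbon bound to a double-bonded chain carbon. In this assay compound 3 gives 5000 nM. Compound 1, bearing 4-nitrophenyl, gives 3520 nM, and the step of a 1.4-fold higher number from compound 1 to compound 3 (0.15 log units; within the scatter) stays within the scatter, so the two sit side by side. For compound 2 the value > 10000 nM is a limit of the assay (the limit of > 10000 nM in this assay, at which 1 of the 3 values shown sits). The step of an at least 2.0-fold lower number from compound 2 to compound 3 (0.30 log units; that floor lies within the scatter) is therefore only a floor. Compound 4, `COc1ccc(C(=O)/C=C/c2cc(Cl)ccc2O)c2c1C=CC(C)(C)O2`, changes compound 3 in one place: 5-chloro-2-hydroxyphenyl in place of pyridin-2-yl on a double-bonded chain carbon bound to a double-bonded chain carbon. Going by the values given here, no measured step shows this change; the one step that exchanges pyridin-2-yl for a phenyl, that from compound 1 to compound 3, is small. A step of a 1.6-fold lower number from compound 3 to compound 4 (0.19 log units; within the scatter) is expected, within or near the scatter, with compound 4 estimated at 3200 nM (range 900 nM to 11000 nM).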

Compound 4, half-maximal inhibitory concentration: 4230 nM
Estimate against measurement, compound 4: 1.3-fold (0.12 log units) below; the measured number falls inside the stated range.
By their numbers in this assay, from the lowest: compounds 1, 4 and 3 (each within the scatter of the next). At a limit, above all of these: compound 2.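

In this assay, putting 5-chloro-2-hydroxyphenyl in place of pyridin-2-yl on a double-bonded chain carbon bound to a double-bonded chain carbon gives a 1.2-fold lower number from compound 3 to compound 4 (0.07 log units; within the scatter), and the comparison with 4-nitrophenyl gives a 1.2-fold higher number from compound 1 to compound 4 (0.08 log units; within the scatter), so an all-carbon ring carrying a hydrogen-bond donor cannot be told apart from either group at this position. The step of an at least 2.3-fold lower number from compound 2 to compound 4 (0.37 log units; beyond the scatter) is only a floor, but unlike the floor to compound 3 it clears the scatter. Compound 2 itself stands at a limit of the assay, not at a number: the limit of > 10000 nM in this assay, at which 1 of the 4 values shown sits.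

The chlorine and the hydroxyl of 5-chloro-2-hydroxyphenyl enter together, so the compounds shown leave open what each contributes alone. They also leave open how an amine or a carboxylic acid at this position would read in this assay.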